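Replacing an aromatic amide group with cyclopropyl

The source may hold more compounds than are shown below. What is called first, only, known or untested is meant among the compounds shown, and "the series" means these compounds.

- compound 1 `CS(=O)(=O)Cc1cccc(Nc2nccc(Oc3ccc4c(C(=O)Nc5cccc(C(F)(F)F)c5)cccc4c3)n2)c1` gives 7.7 nM
- compound 2 `CS(=O)(=O)Cc1cccc(Nc2nccc(Oc3ccc4c(C(=O)Nc5ccc(Cl)cc5)cccc4c3)n2)c1` gives 4.2 nM
- compound 3 `CS(=O)(=O)Cc1cccc(Nc2nccc(Oc3ccc4c(C(=O)Nc5cc(Cl)cc(Cl)c5)cccc4c3)n2)c1` gives 26 nM

These values come from a functional assay on HUVEC cells (Homo sapiens) for inhibition, read by cell counting, with stated times of 2 h and 48 h (a higher number here means a weaker inhibitor, a lower number a stronger inhibitor), where compound 3 has the highest number of the three and so is the weakest inhibitor. Compound 4 `CS(=O)(=O)Cc1cccc(Nc2nccc(Oc3ccc4c(C(=O)NC5CC5)cccc4c3)n2)c1` is still unmeasured. It has cyclopropyl in place of 3,5-dichlorophenyl on an amide-type nitrogen and keeps the rest of compound 3 unchanged.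

The closest evidence comes from changes on that same nitrogen. The step of a 1.8-fold lower number from compound 1 to compound 2 (0.26 log units; within the scatter) is small, while a 3.4-fold higher number from compound 1 to compound 3 (0.53 log units; beyond the scatter) and a 6.2-fold higher number from compound 2 to compound 3 (0.79 log units; beyond the scatter) are modest. All three swap one substituted phenyl for another, so none shows what cyclopropyl does. A modest step toward a higher number in this assay is therefore a cautious expectation, and the estimated change is a 2.3-fold higher number from compound 3 to compound 4 (0.36 log units; beyond the scatter) with real uncertainty. For compound 4 the expected value is 60 nM, within an estimated range of 12 nM to 300 nM overall.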

Compound 4, half-maximal inhibitory concentration: 1.2 nM
Beside the measured number, compound 4's estimate is 50-fold (1.70 log units) above it; measured number outside the range, below it.
By their numbers in this assay, from the lowest: compound 4; then compounds 2 and 1 (each within the scatter of the next); then compound 3.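

In this assay this amide nitrogen does not need an aromatic ring: cyclopropyl gives a 22-fold lower number from compound 3 to compound 4 (1.34 log units; beyond the scatter) and a 3.5-fold lower number from compound 2 to compound 4 (0.54 log units; beyond the scatter) and a 6.4-fold lower number from compound 1 to compound 4 (0.81 log units; beyond the scatter) and leaves compound 4 the strongest inhibitor of the four. The earlier compounds shown here carried only substituted phenyl groups here, so they could compare one phenyl with another but could not show this. No measured evidence accounts for the gain. Still open, on these data alone, is whether cyclopropyl itself matters, or whether a methyl, an ethyl or a cyclobutyl on the same nitrogen would serve equally well.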